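This account rests on a few compounds, and the source may have more. Where it says the series, first, only, none or still open, it means among the compounds named here.

Within the data shown here, compound 2, `CCCCCCCCCCCCCCCCCCNC(=O)[C@@H](NC(=O)c1ccco1)[C@@H](C)O`, is one of two compounds measured in a functional assay on MCF7 cells (Homo sapiens) for cytotoxicity, read by MTT assay, with a stated time of 48 h; a lower number here means a stronger inhibitor, a higher number a weaker inhibitor. In this assay compound 2 gives 21400 nM. Among the measured compounds shown here, the only other measured compound is compound 1, `CCCCCCCCCCCCCCNC(=O)[C@@H](NC(=O)c1cccs1)[C@@H](C)O`, which carries a shorter chain and a different ring, so the two differ in more than one place and no single step can be read between them. In this assay compound 1 gives 36100 nM, a value within the usual scatter of that of compound 2, so the two cannot be told apart. Compound 3, `CCCCCCCCCCCCCCCCCCNC(=O)[C@@H](NC(=O)c1cccs1)[C@@H](C)O`, keeps the long chain of compound 2 and changes only the ring: thiophen-2-yl in place of furan-2-yl on a carbonyl carbon. For the measured compounds named here, with no measured step of this kind on record, the expected step from compound 2 to compound 3 in this assay is small, a 1.2-fold higher number from compound 2 to compound 3 (0.07 log units; within the scatter), not clearly beyond the scatter in either direction. Compound 3 is therefore expected to give about 25000 nM, most likely between 10000 nM and 60000 nM.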

Compound 3, half-maximal inhibitory concentration: 25700 nM
Compound 3: the middle estimate sits 1.0-fold (0.01 log units) below what was measured; measured number inside the range.
By their numbers in this assay, from the lowest: compounds 2, 3 and 1 (each within the scatter of the next).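

In this assay, thiophen-2-yl in place of furan-2-yl on a carbonyl carbon gives a 1.2-fold higher number from compound 2 to compound 3 (0.08 log units; within the scatter) and so stays within the scatter: on the long chain, exchanging these two rings, which differ only in carrying oxygen or sulfur, makes no change that can be detected. Among these compounds, compound 3 also provides the first single-place reading of the chain, since butyl in place of hydrogen on a saturated chain carbon gives a 1.4-fold lower number from compound 1 to compound 3 (0.15 log units; within the scatter) and is also within the scatter. No measurement on hand offers an explanation for either result.

Still open, going by these compounds, is whether a phenyl ring at the same carbonyl carbon would give a number beyond the scatter. The same question applies to a far shorter chain, such as hexyl.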